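The compounds below may be only part of what the source reports. "The series", "measured", "known", "first", "only" and "open" are said of these compounds alone.

In a physicochemical assay for solubility, at pH 6.5 (a lower number here means a less soluble compound, a higher number a more soluble compound), compound 1 `CS(=O)(=O)c1ccc(-c2cnc3ccc(-c4cccc(C(=O)N5CCC(O)CC5)c4)nn23)cc1` gives 178000 nM, and compound 2 `CS(=O)(=O)c1cccc(-c2ccc3ncc(-c4ccc(S(=O)(=O)N5CCNCC5)cc4)n3n2)c1` gives 162000 nM, the two numbers sitting within the scatter of each other. For compound 3 `CS(=O)(=O)c1cccc(-c2ccc3ncc(-c4ccc(N)nc4)n3n2)c1` only a limit is recorded, < 5000 nM, which is the limit of < 5000 nM in this assay, at which 1 of the 3 values shown sits. Compound 4 `C[S+]([O-])c1cccc(-c2ccc3ncc(-c4ccc(S(C)(=O)=O)cc4)n3n2)c1` has not been measured in this assay; it differs from compound 1 in a single place: a group of 3 heavy atoms (1 carbon, 1 oxygen, 1 sulfur; no ring) in place of a group of 9 heavy atoms (6 carbon, 1 nitrogen, 2 oxygen; one six-membered non-aromatic ring with 1 hetero atom), on an aromatic carbon. Within the data shown here, no measured pair of compounds shows a change of this kind, so what follows is an expectation and not a reading. Compound 4 is expected to give a lower number than compound 1, with the step of an 8.9-fold lower number from compound 1 to compound 4 (0.95 log units; beyond the scatter) expected to reach beyond the scatter. The estimate for compound 4 is 20000 nM, with a range from 5000 nM to 80000 nM.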

Compound 4, solubility: 157000 nM
The estimate for compound 4 lay 7.9-fold (0.89 log units) below the measured number; measured number outside the range, above it.
By their numbers in this assay, from the lowest: compounds 4, 2 and 1 (each within the scatter of the next). At a limit, below all of these: compound 3.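

In this assay, exchanging the (4-hydroxypiperidin-1-yl)carbonyl group for a group of 3 heavy atoms on this aromatic carbon gives a 1.1-fold lower number from compound 1 to compound 4 (0.05 log units; within the scatter), a step within the scatter. Among these compounds, this is the first pair to read a change at this position, and it shows that the one-ring group, with its hydrogen-bond donor, is not required for a number of this size here. Nothing measured here gives a reason for this result.

Going by these compounds, what an amine or a carboxylic acid on this aromatic carbon would give remains open. So does whether the same exchange would read alike with another group elsewhere on the shared core.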